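This account rests on a few compounds, and the source may have more. Where it says the series, first, only, none or still open, it means among the compounds named here.

For the measured compounds named here, in a functional assay on A549 cells (Homo sapiens) for antiproliferative activity, read by MTT assay, with a stated time of 72 h (a higher number here means a weaker inhibitor, a lower number a stronger inhibitor), compound 1 `C=CC(=O)Nc1cc(Nc2nccc(NC(=O)c3cccc(OC)c3)n2)c(OC)cc1N1CCN(C)CC1` gives 6450 nM, the higher of the two numbers measured so far. Going by the values given here, its only measured neighbour, compound 2 `C=CC(=O)Nc1cc(Nc2nccc(NC(=O)c3cccc(OC)c3)n2)c(OC)cc1N(C)CCN(C)C`, gives 3000 nM. The next comparison is compound 3 `C=CC(=O)Nc1cc(Nc2nccc(NC(=O)c3ccccc3)n2)c(OC)cc1N1CCN(C)CC1`, which keeps the 4-methylpiperazin-1-yl group of compound 1 and has hydrogen in place of methoxy on an aromatic carbon, turning the 3-methoxyphenyl group into phenyl: hydrogen in place of methoxy on an aromatic carbon.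

Among the compounds with values here, the one measured step is a 2.2-fold lower number from compound 1 to compound 2 (0.33 log units; beyond the scatter). It is modest and concerns a different place, with (2-(dimethylamino)ethyl)(methyl)amino in place of 4-methylpiperazin-1-yl. It therefore shows only the size of change seen so far in this series and says nothing directly about the methoxy group. Within the data shown here, no measured pair tests the loss of that group, so the data set no direction. The working expectation in this assay is no step beyond the scatter, with a wide range to reflect the lack of direct evidence.

The expected step is a 1.2-fold lower number from compound 1 to compound 3 (0.07 log units; within the scatter). For compound 3 the estimated value is 5500 nM, with an expected range of 2200 nM to 14000 nM.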

Compound 3, half-maximal inhibitory concentration: 5970 nM
The estimate for compound 3 lay 1.1-fold (0.04 log units) below the measured number, within the range that was stated.
By their numbers in this assay, from the lowest: compounds 2, 3 and 1 (each within the scatter of the next, the first and the last beyond it).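

In this assay, for the compounds shown here, the first measured pair at this position gives a 1.1-fold lower number from compound 1 to compound 3 (0.03 log units; within the scatter), so with the 4-methylpiperazin-1-yl group held fixed, the 3-methoxyphenyl and phenyl compounds cannot be told apart. The methoxy group, with its 2 heavy atoms and 1 hydrogen-bond acceptor, can therefore be replaced by hydrogen here without a step beyond the scatter, whereas the earlier 2.2-fold lower number from compound 1 to compound 2 (0.33 log units; beyond the scatter) concerned a different place and could not speak to this one. No measured evidence accompanies this result, so the reading stays with the numbers alone.

This holds for one replacement on one background, and the compounds shown do not tell whether hydrogen in place of methoxy reads the same alongside the (2-(dimethylamino)ethyl)(methyl)amino group of compound 2. Also open, from the compounds shown here alone, is whether a different group on this aromatic carbon, such as a carboxylic acid, an amine or a longer alkoxy chain, would leave the number within the scatter or move it beyond.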